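This account rests on a few compounds, and the source may have more. Where it says the series, first, only, none or still open, it means among the compounds named here.

In an ADME assay on HepG2 cells (Homo sapiens) for cytotoxicity, with a stated time of 72 h (a higher number here means that more compound is needed for the effect, a lower number that less compound is needed), compound 1 `Cc1cc(NC(=O)Nc2cccc(C(N)=O)c2)c2ccccc2n1` gives > 25000 nM, which is a limit of the assay and not a number. Compound 2 `Cc1cc(NC(=O)Nc2ccc(F)cc2)c2ccccc2n1` also gives a limit, > 25000 nM. Compound 3 `Cc1cc(NC(=O)Nc2cc(F)cc(F)c2)c2ccccc2n1` gives a limit as well, > 25000 nM. Compound 1 therefore stands with the other two, at the limit of > 25000 nM in this assay, at which 3 of the 3 values shown sit.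

Compound 4 `Cc1cc(NC(=O)Nc2cccc(N(C)C)c2)c2ccccc2n1` has dimethylamino in place of carbamoyl on an aromatic carbon of compound 1: dimethylamino in place of carbamoyl on an aromatic carbon. For the measured compounds named here, no measured pair shows the size of a single change. Given (the limit of > 25000 nM in this assay, at which 3 of the 3 values shown sit), no step beyond the scatter is expected in this assay, though a move to a lower number cannot be excluded. The estimated step is a number no higher from compound 1 to compound 4 (the limit leaves the size open). Compound 4 is expected at 25000 nM, with an estimated range of 12000 nM to 50000 nM.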

Compound 4, half-maximal effective concentration: > 25000 nM
Compound 4: a limit, no number; the forecaster's own chance of this, stated with the estimate: 75%; the middle value lies on the limit itself.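

Compound 1 and compound 4 both give only a limit, so no step between them can be read in this assay: the limit of > 25000 nM in this assay, at which 4 of the 4 values shown sit.

The compounds shown leave open what concentration of any of them gives the half-maximal effect, and so whether dimethylamino in place of carbamoyl changes anything.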